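Working notes: aryl replaced by bromo on the shared core

This account rests on a few compounds, and the source may have more. Where it says the series, first, only, none or still open, it means among the compounds named here.

Compound 1 `Cc1csc(N)c1C(=O)c1ccc(Cl)cc1` and compound 2 `COc1ccc(-c2sc(N)c(C(=O)c3ccc(Cl)cc3)c2C)cc1` share one core. In an assay on CHO cells for displacement of a labelled ligand from adenosine receptor A3 (Homo sapiens), read by scintillation counting, tested at 10 uM (a higher number here means more inhibition at the concentration tested (going by the name of the read-out), a lower number less inhibition), compound 1 gives 1%, and compound 2 gives 1%. The step of no change at the digits printed from compound 1 to compound 2 (within the scatter) is flat, so compound 2 stands level with compound 1 at the digits shown, and neither compound shows any inhibition of note at the concentration tested.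

Compound 3 `Cc1c(Br)sc(N)c1C(=O)c1ccc(Cl)cc1` has not been measured. Against compound 2 it differs by bromo in place of 4-methoxyphenyl on an aromatic carbon. Among the compounds with values here, the single measured step, no change at the digits printed from compound 1 to compound 2 (within the scatter), concerns the same aromatic carbon and was flat; there is no measured step that bears on bromo itself. With the whole series lying at the floor of the read-out, the expected step of a number 1 percentage points higher from compound 2 to compound 3 (within the scatter) is none beyond the scatter. Compound 3 is therefore estimated at 2%, within -8% to 12%.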

Compound 3, a percentage reported as inhibition, at one concentration (the size of the read-out at that concentration, not a potency): 1%
For compound 3 the middle estimate is 1 percentage points above the measured one, and the stated range covers the measured number.
By their numbers in this assay, from the lowest: compounds 1, 2 and 3 (each within the scatter of the next).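

In this assay the aromatic carbon next to the ring sulfur now carries hydrogen, 4-methoxyphenyl or bromo, and the read-out does not separate the three. Bromo in place of 4-methoxyphenyl shows no change at the digits printed from compound 2 to compound 3 (within the scatter) and bromo in place of hydrogen shows no change at the digits printed from compound 1 to compound 3 (within the scatter), so a single bromine atom reads the same as the aryl group and as the unsubstituted carbon. No measurement is at hand that could explain this flat result.

With all three compounds at the floor of the read-out, the set gives no sign of what could raise inhibition at this carbon. From the compounds shown here alone, whether an amine or a carboxylic acid there would read differently stays open, as does a longer chain in place of the methyl group.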